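Amide series: ring size and chloro substitution notes

This account rests on a few compounds, and the source may have more. Where it says the series, first, only, none or still open, it means among the compounds named here.

Four compounds share one core. Compound 1 `CCN(C(=O)CC(CC(=O)NCCN1CCCCC1)c1ccc(Cl)cc1)C1Cc2ccccc2C1` gives 13200 nM in a functional assay on A549 cells (Homo sapiens) for inhibition; on this read-out lower numbers stand for stronger inhibition and higher numbers for weaker inhibition. Compound 2 `CCN(C(=O)CC(CC(=O)NCCN1CCCC1)c1ccc(Cl)cc1)C1Cc2ccccc2C1` gives 22600 nM in this assay. Compound 3 `CCN(C(=O)CC(CC(=O)NCCN1CCCC1)c1ccccc1)C1Cc2ccccc2C1` reaches only a limit in this assay, namely > 100000 nM. Compound 4 `CCN(C(=O)CC(CC(=O)NCCN1CCCCC1)c1ccccc1)C1Cc2ccccc2C1` is not yet measured.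

The cores of compound 2 and compound 3 differ by hydrogen in place of chloro on an aromatic carbon, and that step is an at least 4.4-fold higher number from compound 2 to compound 3 (0.64 log units; beyond the scatter). The change piperidin-1-yl in place of pyrrolidin-1-yl on a saturated chain carbon, two bonds along the chain from an amide-type nitrogen made a 1.7-fold lower number from compound 2 to compound 1 (0.23 log units; within the scatter). The same change, (piperidin-1-yl in place of pyrrolidin-1-yl on a saturated chain carbon, two bonds along the chain from an amide-type nitrogen), leads from compound 3 to compound 4, at the same place in both pairs. Since compound 3 sits at the limit of > 100000 nM in this assay, at which 1 of the 3 values shown sits, compound 4 is expected to stay near that limit, with an estimated step that the limit leaves unreadable from compound 3 to compound 4. Compound 4 is estimated at 110000 nM, expected to lie between 50000 nM and 300000 nM.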

Compound 4, half-maximal inhibitory concentration: 84500 nM
Compound 4: the middle estimate sits 1.3-fold (0.11 log units) above what was measured; measured number inside the range.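

Compound 3 stands at a limit of the assay (> 100000 nM), so the change from pyrrolidin-1-yl to piperidin-1-yl can be read on its core only as a floor. In this assay that change gives an at least 1.1-fold lower number from compound 3 to compound 4 (0.07 log units; that floor lies within the scatter) and so shows neither agreement nor disagreement between the two cores: the same change on two cores in this assay, a 1.7-fold lower number (0.23 log units; within the scatter) from compound 2 to compound 1 and an at least 1.1-fold lower number (0.07 log units; that floor lies within the scatter) from compound 3 to compound 4; the limit leaves it open whether they differ. Hydrogen in place of chloro gives a 6.4-fold higher number from compound 1 to compound 4 (0.81 log units; beyond the scatter) and points the same way on both cores, though its size cannot be compared: the same change on two cores in this assay, an at least 4.4-fold higher number (0.64 log units; beyond the scatter) from compound 2 to compound 3 and a 6.4-fold higher number (0.81 log units; beyond the scatter) from compound 1 to compound 4; the limit leaves it open whether they differ.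

The compounds shown leave open whether morpholin-4-yl or dimethylamino in place of piperidin-1-yl, or a longer chain, would follow the same course. Going by these compounds, whether fluoro or methoxy could stand in for chloro also remains open.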